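Ether variation on the shared core: cyclopentyl to but-3-yn-1-yl

A few compounds are considered here, and "the series" means these few. Any claim that something is new, unique, unknown or untested is made for them only; others in the source may bear on it.

Measured compounds:
- compound 1 `O=C1C=C[C@@H](OC2CCCC2)O[C@@H]1CO`: 19800 nM
- compound 2 `CC(C)O[C@@H]1C=CC(=O)[C@@H](CO)O1`: 24200 nM
- compound 3 `C=CCO[C@@H]1C=CC(=O)[C@@H](CO)O1`: 10300 nM

In a functional assay on NCI-H292 cells (Homo sapiens) for inhibition, read by MTT assay, with a stated time of 72 h (a higher number here means a weaker inhibitor, a lower number a stronger inhibitor), compound 1 stands second highest of the three numbers; compound 2 sits nearest to it, compound 3 furthest. The step of a 1.2-fold higher number from compound 1 to compound 2 (0.09 log units; within the scatter) shows that exchanging the cyclopentyl ether for isopropyl leaves the number where it was. The step of a 1.9-fold lower number from compound 1 to compound 3 (0.28 log units; within the scatter) shows a small move downward, and the step of a 2.3-fold lower number from compound 2 to compound 3 (0.37 log units; beyond the scatter) a modest one in the same direction.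

Compound 4 `C#CCCO[C@@H]1C=CC(=O)[C@@H](CO)O1` has not been measured. It differs from compound 1 by but-3-yn-1-yl in place of cyclopentyl on an oxygen on a saturated carbon. Within the data shown here, the steps that bear on this are those from the cyclopentyl ether to the open-chain ethers of compound 2 and compound 3, all of them small; the unsaturated chain of compound 3 gave the lowest number so far, and but-3-yn-1-yl is likewise an open unsaturated chain. A small downward step, probably within the scatter, is therefore expected in this assay, that is a 1.5-fold lower number from compound 1 to compound 4 (0.18 log units; within the scatter). For compound 4 the estimated value is 13000 nM, with an expected range from 6000 nM to 28000 nM.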

Compound 4, half-maximal inhibitory concentration: 12700 nM
The estimate for compound 4 lay 1.0-fold (0.01 log units) above the measured number; measured number inside the range.
By their numbers in this assay, from the lowest: compounds 3, 4, 1 and 2 (each within the scatter of the next, the first and the last beyond it).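

In this assay, a triple bond at this ether position gives a number that cannot be separated from any of the other three ethers: the cyclopentyl ether (a 1.6-fold lower number from compound 1 to compound 4 (0.19 log units; within the scatter)), the isopropyl ether (a 1.9-fold lower number from compound 2 to compound 4 (0.28 log units; within the scatter)) and the allyl ether (a 1.2-fold higher number from compound 3 to compound 4 (0.09 log units; within the scatter)) all lie within the scatter of it. Ring, branched chain, double bond and triple bond on this oxygen thus give numbers close together, with the pair against this reading being compound 2 and compound 3 (a 2.3-fold lower number from compound 2 to compound 3 (0.37 log units; beyond the scatter)), which lie just beyond the scatter of each other. Nothing available explains why these groups read so alike.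

Going by these compounds, whether an amine, a carboxylic acid or a longer chain on this oxygen would stay with these four remains open. On these data alone, all four compounds differ only at this ether, so changes elsewhere on the shared core also remain open.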